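Cytotoxicity of the shared core: nitro to difluoro exchange

The compounds below may be only part of what the source reports. "The series", "measured", "known", "first", "only" and "open" are said of these compounds alone.

Measured so far:
compound 1 `COC(=O)c1ccc(NCc2cncn2Cc2ccc([N+](=O)[O-])cc2)cc1-c1ccccc1`: > 10000 nM
compound 2 `O=[N+]([O-])c1ccc(Cn2cncc2CNc2cccc(-c3ccccc3)c2)cc1`: 10000 nM
compound 3 `Cc1cccc(-c2cc(NCc3cncn3Cc3ccc(-c4ccccc4)cc3)ccc2-c2nc3ccccc3s2)c1C`: > 1000 nM

In a toxicity assay on NIH3T3 cells (Mus musculus) for cytotoxicity, read by resazurin assay (on this read-out lower numbers stand for an effect already at smaller amounts and higher numbers for an effect only at larger amounts of compound), compound 1 gives > 10000 nM; this is a limit of the assay, not a number, and compound 1 stands at the limit of > 10000 nM in this assay, at which 1 of the 3 values shown sits. Compound 2 gives 10000 nM. Compound 3 gives > 1000 nM, again a limit and not a number, so compound 3 sits at the limit of > 1000 nM in this assay, at which 1 of the 3 values shown sits. With only a limit for compound 1, its place on the measured values can be read no further than the top end of what was tested.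

Going by the values given here, the one measured step, a number no higher from compound 1 to compound 2 (the limit leaves the size open), is the only step that runs from compound 1, and its size is open.

Compound 4 `COC(=O)c1ccc(NCc2cncn2Cc2ccc(F)cc2F)cc1-c1ccccc1` differs from compound 1 by 2,4-difluorophenyl in place of 4-nitrophenyl on a saturated chain carbon bound to an aromatic nitrogen. Among the compounds with values here, no measured step touches this change, and the step from compound 1 bears on it only in showing that compound 1 already gave no number. The step that the limit leaves unreadable from compound 1 to compound 4 is therefore expected to be none beyond the scatter, with a fair chance that this assay again reports a limit. For compound 4 the estimate in this assay is 12000 nM, within 5000 nM to 30000 nM.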

Compound 4, half-maximal effective concentration: > 1000 nM
Compound 4: only a limit was reported; the forecaster's own chance of this, stated with the estimate: 60%; the middle value does not contradict the limit.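

In this assay compound 4 gives > 1000 nM, a limit and not a number. Compound 1 gives > 10000 nM, also a limit, so no step can be read between compound 1 and compound 4. The compounds shown leave open whether 2,4-difluorophenyl in place of 4-nitrophenyl shifts cytotoxicity on the shared core at all.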